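Chloro removal on the fused ring of compound 3

The source may report more compounds than this note shows. Statements on the series, on what has been measured and on what is new or still open speak of the compounds shown alone.

Three members of the series have numbers in an assay on membranes from brain for displacement of a labelled ligand from adenosine receptor A1 (Rattus norvegicus), read by scintillation counting, with a stated time of 90 min; on this read-out higher numbers stand for weaker inhibition and lower numbers for stronger inhibition. Compound 1 `COc1cccc(CCCC(=O)Nc2nc3ccccc3c(=O)s2)c1` gives 22.5 nM in this assay. Compound 2 `CN(C(=O)CCCc1ccccc1)c1nc2ccccc2c(=O)s1`, which carries a methyl on the amide nitrogen, reaches only the limit of the assay, > 10000 nM, and so no number is known for it; that limit is noted as the limit of > 10000 nM in this assay, at which 1 of the 3 values shown sits. Compound 3 `O=C(CCCc1ccccc1)Nc1nc2cc(Cl)ccc2c(=O)s1` gives 64.4 nM in this assay, the higher of the two numbers shown, with compound 1 lower by a gap that lies beyond the scatter.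

Compound 4 `O=C(CCCc1ccccc1)Nc1nc2ccccc2c(=O)s1` has not been measured. It differs from compound 3 in one place: hydrogen in place of chloro on an aromatic carbon. Going by the values given here, no measured pair in this set shows the effect of such a change, so the expected step rests on the neighbourhood of compound 1 and compound 3 alone. A small step is expected, toward a lower number, a 1.8-fold lower number from compound 3 to compound 4 (0.26 log units; within the scatter), without confidence that it exceeds the scatter. Compound 4 is therefore estimated at 35 nM in this assay, within a range of 12 nM to 110 nM.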

Compound 4, inhibition constant: 229 nM
Estimate against measurement, compound 4: 6.5-fold (0.82 log units) below, outside the stated range (above it).
By their numbers in this assay, from the lowest: compound 1; then compound 3; then compound 4. At a limit, above all of these: compound 2.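

In this assay, the chloro on this aromatic carbon, meta to a fused ring and para to a fused ring, counts in favour of a lower number: hydrogen in its place gives a 3.6-fold higher number from compound 3 to compound 4 (0.55 log units; beyond the scatter). Hydrogen in place of methoxy, at a different place in the series, gives a 10-fold higher number from compound 1 to compound 4 (1.01 log units; beyond the scatter), so compound 4, which carries neither group, has a higher number than both compound 1 and compound 3. Hydrogen in place of methyl on the amide-type nitrogen gives an at least 43-fold lower number from compound 2 to compound 4 (1.64 log units; beyond the scatter), where compound 2 stands at a limit and not at a number: the limit of > 10000 nM in this assay, at which 1 of the 4 values shown sits.

On these data alone, whether bromo or an amine on the same aromatic carbon would keep the lower number remains open. Also open, as far as these compounds go, is how chloro and methoxy behave together on one compound, or with a longer chain.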